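The source may report more compounds than this note shows. Statements on the series, on what has been measured and on what is new or still open speak of the compounds shown alone.

Compounds measured so far in a functional assay on A549 cells (Homo sapiens) for antiproliferative activity, read by MTT assay, with a stated time of 72 h; on this read-out lower numbers stand for stronger inhibition and higher numbers for weaker inhibition:

- compound 1, `CN(C(=O)c1ccc(F)cc1)c1ccc2[nH]c(-c3n[nH]c4ccccc34)cc2n1`: 9650 nM
- compound 2, `COc1cccc(C(=O)N(C)c2ccc3[nH]c(-c4n[nH]c5ccccc45)cc3n2)c1`: 14900 nM
- compound 3, `CN(c1ccc2[nH]c(-c3n[nH]c4ccccc34)cc2n1)S(=O)(=O)c1ccc(Cl)cc1`: 18200 nM

All three compounds share the same core and differ only in the group carried on the methylated nitrogen on the aromatic ring. Compound 3 gives the highest of the three numbers in this assay, but none of its steps to the others leaves the scatter: from compound 2 to compound 3 the change is a 1.2-fold higher number from compound 2 to compound 3 (0.09 log units; within the scatter), and from compound 1 to compound 3 it is a 1.9-fold higher number from compound 1 to compound 3 (0.28 log units; within the scatter). Between compound 1 and compound 2 the step is a 1.5-fold higher number from compound 1 to compound 2 (0.19 log units; within the scatter).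

Compound 4, `CN(c1ccc2[nH]c(-c3n[nH]c4ccccc34)cc2n1)S(=O)(=O)c1ccc(Br)cc1`, is the next compound and has not yet been measured. It differs from compound 3 in one place: bromo in place of chloro on an aromatic carbon. Among the measured compounds shown here, no measured step changes a halogen on this ring, so none bears directly on it. The closest steps, those from compound 1 to compound 3 and from compound 2 to compound 3, each changed both the linker and the aryl group and still stayed within the scatter, which suggests that a change of one halogen for another should do no more. Compound 4 is therefore expected to sit close to compound 3, with a step of about a 1.1-fold lower number from compound 3 to compound 4 (0.03 log units; within the scatter) in this assay. The estimate for compound 4 is 17000 nM, with a range from 8000 nM to 40000 nM.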

Compound 4, half-maximal inhibitory concentration: 19700 nM
The estimate for compound 4 lay 1.2-fold (0.06 log units) below the measured number, and the stated range covers the measured number.
By their numbers in this assay, from the lowest: compounds 1, 2, 3 and 4 (each within the scatter of the next, the first and the last beyond it).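

In this assay, among the compounds shown here, the exchange of a single halogen on the aromatic carbon para to a large group gives a 1.1-fold higher number from compound 3 to compound 4 (0.03 log units; within the scatter), so this position tolerates bromo in place of chloro with no change that can be read, and the earlier compounds held no such direct comparison. For the compounds shown here, the (4-bromophenyl)sulfonyl group in place of (3-methoxyphenyl)carbonyl likewise gives a 1.3-fold higher number from compound 2 to compound 4 (0.12 log units; within the scatter), whereas in place of (4-fluorophenyl)carbonyl it gives a 2.0-fold higher number from compound 1 to compound 4 (0.31 log units; beyond the scatter), the first step to pass the scatter, though a modest one that alters both the linker and the aryl group and so cannot be assigned to either part. Nothing measured here bears on what lies behind these steps.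

The compounds shown leave open whether an amine or a carboxylic acid in place of the halogen on this ring would move the number beyond the scatter, as two halogens alone say little about how wide a range of groups the position accepts. They also leave open how a (4-fluorophenyl)sulfonyl group would read, which would separate the effect of the linker from that of the aryl group.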